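The compounds below may be only part of what the source reports. "The series", "measured", "known", "first", "only" and "open" are said of these compounds alone.

Compound 1 `O=C(O)CCc1ccc(OCc2nc(-c3ccccc3)no2)cc1`: 1130 nM
Compound 2 `CC(Oc1ccc(CCC(=O)O)cc1)c1nc(-c2ccccc2)no1`: 2390 nM

In a functional assay on CHO cells for agonist activity at Free fatty acid receptor 1 (Homo sapiens), read by FLIPR and calcium flux, in the presence of a further agent that is not named here (on this read-out lower numbers stand for an effect already at smaller amounts and higher numbers for an effect only at larger amounts of compound), compound 1 gives the lower of the two numbers. Within the data shown here, the single measured step, a 2.1-fold higher number from compound 1 to compound 2 (0.33 log units; beyond the scatter), comes from a methyl in place of hydrogen on a saturated chain carbon bound to an aromatic carbon and an oxygen on an aromatic ring. Compound 3 `O=C(O)CCc1ccc(OCc2nc(-c3cccc(Br)c3)no2)cc1` differs from compound 1 by bromo in place of hydrogen on an aromatic carbon. Among the measured compounds shown here, no measured step concerns that ring, so the step between compound 1 and compound 2 offers no guide, and compound 3 is expected to change little, a 1.3-fold lower number from compound 1 to compound 3 (0.10 log units; within the scatter). Compound 3 is estimated at 900 nM, between 300 nM and 3000 nM.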

Compound 3, half-maximal effective concentration: 1260 nM
Beside the measured number, compound 3's estimate is 1.4-fold (0.15 log units) below it; the range from low to high includes it.
By their numbers in this assay, from the lowest: compounds 1, 3 and 2 (each within the scatter of the next, the first and the last beyond it).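

In this assay, the change from phenyl to 3-bromophenyl gives a 1.1-fold higher number from compound 1 to compound 3 (0.05 log units; within the scatter), so at this aromatic carbon, meta to a large group, bromo reads the same as hydrogen within the scatter. Among these compounds, the earlier pair spoke only to the saturated chain carbon, whereas this step is the first reading on the phenyl ring. No evidence at hand bears on this result. As far as these compounds go, whether an amine or a methoxy group at this carbon would read the same remains open, as does bromo at the ring's other carbons.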